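The source may report more compounds than this note shows. Statements on the series, on what has been measured and on what is new or still open speak of the compounds shown alone.

Compound 1: `O=C1CCC2(CC1)OOC1(O2)C2CC3CC(C2)CC1C3` — > 100000 nM
Compound 2: `O=C(O)[C@H]1CC[C@]2(CC1)OO[C@]1(O2)C2CC3CC(C2)CC1C3` — > 100000 nM

In a functional assay on SW480 cells (Homo sapiens) for cytotoxicity, read by MTT assay, with a stated time of 48 h (a lower number here means a stronger inhibitor, a higher number a weaker inhibitor), compound 1 gives > 100000 nM, which is a limit of the assay rather than a number. Compound 2 in this assay likewise gives > 100000 nM, again only a limit. Compound 2 therefore stands at the limit of > 100000 nM in this assay, at which 2 of the 2 values shown sit, with nothing measured that separates it from compound 1. Compound 3, `O=C(NO)[C@H]1CC[C@]2(CC1)OO[C@]1(O2)C2CC3CC(C2)CC1C3`, differs from compound 2 by hydroxyamino in place of hydroxy on a carbonyl carbon. Within the data shown here, no step between measured compounds is known, so no direction can be read from the data. Compound 3 is expected near the limit, estimated at 60000 nM with a range of 10000 nM to 200000 nM. This estimate means a step of an at least 1.6-fold lower number from compound 2 to compound 3 (0.22 log units; that floor lies within the scatter) toward stronger inhibition, small and uncertain.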

Compound 3, half-maximal inhibitory concentration: > 50000 nM
Compound 3: no number, only a limit; the forecaster's own chance of this, stated with the estimate: 55%; the middle value lies beyond the limit too.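

Among these compounds, compound 2 and compound 3 each give only a limit, not a number, so no step between them can be read. As far as these compounds go, whether hydroxyamino in place of hydroxy on a carbonyl carbon changes the result in this assay stays open.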